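Swapping the dichlorophenyl for cyclohexyl in compound 2

This account rests on a few compounds, and the source may have more. Where it says the series, first, only, none or still open, it means among the compounds named here.

Of the compounds shown here, three have so far been measured in an assay on CHO cells for displacement of a labelled ligand from histamine receptor H3 (Macaca mulatta), read by scintillation counting, with a stated time of 1 h; a higher number here means a weaker inhibitor, a lower number a stronger inhibitor. Compound 1 `O=C(Nc1ccc(OCCCN2CCCCC2)cc1)Nc1cc(Cl)cc(Cl)c1` gives 3.4 nM. Compound 2 `CC1CCCN1C1CCN(c2ccc(NC(=O)Nc3cc(Cl)cc(Cl)c3)cc2)C1` gives 19.1 nM, the second highest of the three numbers; its nearest neighbour is compound 3 `Cc1cc(NC(=O)Nc2cc(Cl)cc(Cl)c2)ccc1N1CCC(N2CCCC2C)C1`, which gives 43 nM, and its furthest is compound 1. For the measured compounds named here, the only single-point step among them, a 2.3-fold higher number from compound 2 to compound 3 (0.35 log units; beyond the scatter), puts a methyl in place of hydrogen on an aromatic carbon.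

Compound 4 `CC1CCCN1C1CCN(c2ccc(NC(=O)NC3CCCCC3)cc2)C1` has not yet been measured. It differs from compound 2 in one place: cyclohexyl in place of 3,5-dichlorophenyl on an amide-type nitrogen. Going by the values given here, no measured step touches this part of the molecule; the step from compound 2 to compound 3 and the gap between compound 2 and compound 1 both concern other parts of the shared core and so give no direct guide. It is therefore expected, with wide uncertainty, that the number for compound 4 rises modestly, estimated as a 2.1-fold higher number from compound 2 to compound 4 (0.32 log units; beyond the scatter). Compound 4 is expected to give 40 nM, within a range from 10 nM to 160 nM.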

Compound 4, inhibition constant: 4.1 nM
Beside the measured number, compound 4's estimate is 9.8-fold (0.99 log units) above it; measured number outside the range, below it.
By their numbers in this assay, from the lowest: compounds 1 and 4 (each within the scatter of the next); then compound 2; then compound 3.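

In this assay, for the compounds shown here, the end of the urea that carries 3,5-dichlorophenyl proves open to change: cyclohexyl in its place on the amide-type nitrogen gives a 4.7-fold lower number from compound 2 to compound 4 (0.67 log units; beyond the scatter) and so moves the number down, where the only earlier single-place step, a 2.3-fold higher number from compound 2 to compound 3 (0.35 log units; beyond the scatter), moved it up on another part of the molecule. For this pair, then, neither an aromatic ring nor chlorine is needed on this nitrogen for a low number. Nothing at hand offers an explanation for this drop.

The change removes the aromatic ring and both chlorine atoms together, so the pair does not separate their contributions, and unsubstituted phenyl or cyclopentyl on the same nitrogen would be the next groups to read. On these data alone, whether the aromatic methyl of compound 3 would have the same effect alongside cyclohexyl also remains open.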